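Removing the oxetanyloxy group from the fused ring of compound 3

The source may hold more compounds than are shown below. What is called first, only, known or untested is meant among the compounds shown, and "the series" means these compounds.

Measured compounds:
- compound 1 `Cc1nn(CC(=O)N2CCN(c3sc(C(F)(F)F)nc3-c3nc4ccccc4[nH]3)C[C@H]2C)cc1CN(C)C` — 2.7 nM
- compound 2 `C[C@@H]1CN(c2sc(C(F)(F)F)nc2-c2nc3ccccc3[nH]2)CCN1C(=O)CN1CCC(F)(F)CC1` — 15 nM
- compound 3 `Cc1nc(C)n(CC(=O)N2CCN(c3sc(C(F)(F)F)nc3-c3nc4ccc(OC5COC5)cc4[nH]3)C[C@H]2C)n1` — 68 nM

In a functional assay on CHO-K1 cells for antagonist activity at C-X-C chemokine receptor type 3 (Homo sapiens), read by FLIPR, with a stated time of 10 min, in the presence of a further agent that is not named here (a higher number here means a weaker inhibitor, a lower number a stronger inhibitor), compound 3 gives 68 nM, the highest number of the three. Compound 2 sits nearest with 15 nM, compound 1 furthest with 2.7 nM; both gaps are beyond the scatter, so compound 3 is the weakest inhibitor in this set.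

Compound 4 `Cc1nc(C)n(CC(=O)N2CCN(c3sc(C(F)(F)F)nc3-c3nc4ccccc4[nH]3)C[C@H]2C)n1` is compound 3 with hydrogen in place of (oxetan-3-yl)oxy on an aromatic carbon. The fused system of compound 4 is thereby the same as in compound 1 and compound 2, while its side chain stays that of compound 3.

Among the measured compounds shown here, no measured pair differs only at this aromatic carbon, so the effect of the change is not isolated by the data. For the measured compounds named here, the one measured step, a 5.6-fold higher number from compound 1 to compound 2 (0.74 log units; beyond the scatter), concerns the side chain and shows that this part moves the number by a modest amount. Compound 1 and compound 2, both carrying the unsubstituted fused system, give lower numbers than compound 3, which suggests that the change toward compound 4 lowers the number, with the side chain of compound 3 still untested on that fused system.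

Compound 4 is therefore expected to reach about 20 nM (range 6 nM to 65 nM), a step of a 3.4-fold lower number from compound 3 to compound 4 (0.53 log units; beyond the scatter) in this assay, estimated with wide uncertainty.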

Compound 4, half-maximal inhibitory concentration: 3.2 nM
The estimate for compound 4 lay 6.3-fold (0.80 log units) above the measured number; the whole stated range lies above it.
By their numbers in this assay, from the lowest: compounds 1 and 4 (each within the scatter of the next); then compound 2; then compound 3.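

In this assay, hydrogen in place of (oxetan-3-yl)oxy on an aromatic carbon gives the first reading isolated to this position (a step of a 21-fold lower number from compound 3 to compound 4 (1.33 log units; beyond the scatter)), showing that this substituent carries a large penalty on the side chain of compound 3. On the unsubstituted fused system, the side chain can now be compared directly: 3,5-dimethyl-1H-1,2,4-triazol-1-yl in place of 4,4-difluoropiperidin-1-yl gives a 4.7-fold lower number from compound 2 to compound 4 (0.67 log units; beyond the scatter), whereas in place of 4-((dimethylamino)methyl)-3-methyl-1H-pyrazol-1-yl it gives a 1.2-fold higher number from compound 1 to compound 4 (0.07 log units; within the scatter), so the dimethylamino group of compound 1 is not needed to reach this level of inhibition. Nothing available bears on the reason for the size of the oxetanyloxy step.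

Going by these compounds, it remains open whether the penalty belongs to (oxetan-3-yl)oxy itself or to any group on this aromatic carbon, a question that a fluorine, a methoxy group or a primary amine there would address. On these data alone, it is also open whether the same penalty appears with the 4,4-difluoropiperidin-1-yl side chain of compound 2 or the pyrazole side chain of compound 1.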